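A few compounds are considered here, and "the series" means these few. Any claim that something is new, unique, unknown or untested is made for them only; others in the source may bear on it.

Compound 2, with the structure `CC(C)C(c1ccc(-c2ccc3cccc(F)c3c2)[nH]c1=O)N1CCCCC1=O`, gives 6.4 nM in an assay on CHO cells for displacement of a labelled ligand from prostaglandin E2 receptor EP3 subtype (Homo sapiens), read by radioligand binding; on this read-out lower numbers stand for stronger inhibition and higher numbers for weaker inhibition. Among the two compounds measured here, this is the lower number; compound 1, with the structure `CC(C)C(c1ccc(-c2ccc3cccc(F)c3c2)[nH]c1=O)N1CCCCS1(=O)=O`, gives 14 nM in the same assay, and the step of a 2.2-fold lower number from compound 1 to compound 2 (0.34 log units; beyond the scatter) is the only change recorded at the position in question. Compound 3, with the structure `CC(C)C(c1ccc(-c2ccc3cccc(F)c3c2)[nH]c1=O)N1CCN/C1=N\C#N`, is not yet measured. It differs from compound 2 by a group of 8 heavy atoms (4 carbon, 4 nitrogen; one five-membered non-aromatic ring with 2 hetero atoms) in place of a group of 7 heavy atoms (5 carbon, 1 nitrogen, 1 oxygen; one six-membered non-aromatic ring with 1 hetero atom), on a saturated chain carbon bound to an aromatic carbon and a saturated chain carbon. Going by the values given here, no measured step involves the group that enters, so the only guide is that the single change made at this position, from compound 1 to compound 2, moved the number modestly. A step of similar or smaller size is therefore expected, in either direction, with the chance that it stays within the scatter. The expected step of a 1.9-fold higher number from compound 2 to compound 3 (0.27 log units; within the scatter) is small. Compound 3 is estimated at 12 nM, with a range from 4 nM to 40 nM.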

Compound 3, inhibition constant: 23 nM
Estimate against measurement, compound 3: 1.9-fold (0.28 log units) below, within the range that was stated.
By their numbers in this assay, from the lowest: compound 2; then compounds 1 and 3 (each within the scatter of the next).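

Exchanging the 2-oxopiperidin-1-yl group for the five-membered ring group of four carbon and four nitrogen atoms gives a 3.6-fold higher number from compound 2 to compound 3 (0.56 log units; beyond the scatter) in this assay, so compound 2 now holds the lowest number, with steps beyond the scatter to both other compounds. The same group in place of the sulfur-containing six-membered ring gives a 1.6-fold higher number from compound 1 to compound 3 (0.22 log units; within the scatter), so these two quite different rings cannot be told apart on this read-out. No measurement here explains why the groups give these numbers.

Each step swaps a whole ring group, and the compounds shown do not separate the effect of ring size from that of the atoms the ring carries. Also open, as far as these compounds go, is how a pyrrolidin-2-one ring, the five-membered counterpart of the 2-oxopiperidin-1-yl group, would read at this place.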